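The source may hold more compounds than are shown below. What is called first, only, known or untested is meant among the compounds shown, and "the series" means these compounds.

Values in a functional assay on UACC-62 cells (Homo sapiens) for inhibition, read by sulforhodamine B assay, with a stated time of 48 h; a lower number here means a stronger inhibitor of growth, a higher number a weaker inhibitor of growth:
- compound 1 `O=C(Cc1csc2nc(-c3ccc(Br)cc3)cn12)N/N=C/c1ccccc1`: 11500 nM
- compound 2 `O=C(Cc1csc2nc(-c3ccc(Br)cc3)cn12)N/N=C/c1ccccc1O`: 2090 nM
- compound 3 `O=C(Cc1csc2nc(-c3ccc(Br)cc3)cn12)N/N=C/c1ccc(O)cc1`: not yet measured

In this assay, compound 2 has the lower number of the two measured, at 2090 nM. Compound 3 has 4-hydroxyphenyl in place of 2-hydroxyphenyl on a carbon with a double bond to nitrogen.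

Among the compounds with values here, the only measured step that bears on this change is the modest 5.5-fold lower number from compound 1 to compound 2 (0.74 log units; beyond the scatter), with hydroxy in place of hydrogen on an aromatic carbon. That step does not show whether the lower number would survive with the hydroxy placed differently, so the read-across is thin. Compound 3 is expected to keep part of that gain. The expected shift is a 2.2-fold higher number from compound 2 to compound 3 (0.33 log units; beyond the scatter), toward a higher number, and it may not clear the scatter. For compound 3 the estimate is 4500 nM, with an expected range of 1500 nM to 13000 nM.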

Compound 3, concentration for 50% growth inhibition: 9120 nM
For compound 3 the middle estimate is 2.0-fold (0.31 log units) below the measured one, within the range that was stated.
By their numbers in this assay, from the lowest: compound 2; then compounds 3 and 1 (each within the scatter of the next).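

In this assay, the hydroxy gain seen earlier turns out to depend on the placement of the group: the change to 4-hydroxyphenyl on the carbon with a double bond to nitrogen gives a 4.4-fold higher number from compound 2 to compound 3 (0.64 log units; beyond the scatter) and so gives back most of that gain. Set against the parent without hydroxy, the same group gives a 1.3-fold lower number from compound 1 to compound 3 (0.10 log units; within the scatter) and so brings no change that can be read, which leaves compound 2 as the only one of the three set apart from the others by steps beyond the scatter. No supporting data bear on why the two placements differ.

Still open, on these data alone, is whether the lower number of compound 2 needs the hydroxy itself, which 2-methoxyphenyl or 2-aminophenyl in place of 2-hydroxyphenyl would test. As far as these compounds go, it is also open whether the same difference between placements holds with a group other than bromine on the shared core.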